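Sec-butyl for phenyl: expected cytotoxicity of compound 3

This account rests on a few compounds, and the source may have more. Where it says the series, first, only, none or still open, it means among the compounds named here.

For the measured compounds named here, compound 2 `O=C1NC(c2ccccc2)C(=O)N1Cc1ccccc1` is measured in a functional assay on HEL cells (Homo sapiens) for cytotoxicity (on this read-out lower numbers stand for higher toxicity in this test and higher numbers for lower toxicity in this test), and gives 12.5 ug/mL; it is the only value in this assay reported as a number. Compound 1 `CC(C)C1NC(=O)N(C2CCCC2)C1=O` gives > 50 ug/mL in this assay, which is a limit rather than a number. Of the two values shown, one is therefore a number and one sits at the limit (the limit of > 50 ug/mL in this assay, at which 1 of the 2 values shown sits). Going by the values given here, no step between measured compounds differing in one place exists here, so no measured step size is available.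

Compound 3 `CCC(C)C1NC(=O)N(Cc2ccccc2)C1=O` is not yet measured. Compared with compound 2 it carries sec-butyl in place of phenyl on a saturated ring carbon, that is, sec-butyl in place of phenyl on a saturated ring carbon. Since compound 1 sits at the limit (the limit of > 50 ug/mL in this assay, at which 1 of the 2 values shown sits), compound 3 is expected to move in that direction, toward lower toxicity, a step of a 3.2-fold higher number from compound 2 to compound 3 (0.51 log units; beyond the scatter) beyond the scatter. The estimate for compound 3 is 40 ug/mL, within 15 ug/mL to 100 ug/mL, with a fair chance that only a limit is returned.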

Compound 3, half-maximal cytotoxic concentration: 50 ug/mL
Beside the measured number, compound 3's estimate is 1.3-fold (0.10 log units) below it; the measured number falls inside the stated range.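

In this assay, for the compounds shown here, the step of a 4.0-fold higher number from compound 2 to compound 3 (0.60 log units; beyond the scatter) is the first measured change at this saturated ring carbon, with the rest of compound 2 left intact. It shows that this position alone can shift the read-out beyond the scatter, and that the shift on going from phenyl to sec-butyl runs toward lower toxicity in this test. Any further move in that direction may be hard to read, because the number for compound 3 stands at the edge of what the test reports: the limit of > 50 ug/mL in this assay, at which 1 of the 3 values shown sits.

With a single pair, the step cannot be divided between loss of the aromatic ring and the change from ring to open branched chain. Going by these compounds, how an unbranched butyl chain, a cyclohexyl group, an amine or a carboxylic acid at this ring carbon would read remains open.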